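Chain lengthening toward compound 4 in the methylpiperazine series

The source may report more compounds than this note shows. Statements on the series, on what has been measured and on what is new or still open speak of the compounds shown alone.

Measured compounds:
- compound 1 `COc1c(OCCCCN2CCN(C)CC2)cc(O)c2c(=O)cc(-c3ccc(Cl)cc3)oc12`: in a functional assay on B16 cells (Mus musculus) for cytotoxicity, read by MTT assay, with a stated time of 72 h (on this read-out higher numbers stand for weaker inhibition and lower numbers for stronger inhibition), compound 1 gives 2090 nM
- compound 2 `CN(C)CCCOc1c(OCc2ccccc2)cc(O)c2c(=O)cc(-c3ccccc3)oc12`: in this assay compound 2 gives 5420 nM
- compound 3 `CN1CCN(CCCOc2c(OCc3ccccc3)cc(O)c3c(=O)cc(-c4ccccc4)oc23)CC1`: in this assay compound 3 gives 3760 nM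

Compound 3 sits second of the three numbers, close to compound 2 and also close to compound 1; none of these gaps reaches beyond the scatter, so no order among them can be read.

Compound 4 `CN1CCN(CCCCOc2c(OCc3ccccc3)cc(O)c3c(=O)cc(-c4ccccc4)oc23)CC1` differs from compound 3 by (4-methylpiperazin-1-yl)methyl in place of 4-methylpiperazin-1-yl on a saturated chain carbon, three bonds along the chain from an oxygen on an aromatic ring. Within the data shown here, no measured pair isolates this lengthening of the chain. Among the measured compounds shown here, the one measured step at this position, a 1.4-fold lower number from compound 2 to compound 3 (0.16 log units; within the scatter), concerns the amine itself and is within the scatter. Compound 1 carries the longer chain with the same amine, yet differs from compound 3 in two further places, so its value and that of compound 3 only show that both lie close together.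

On this basis the step of a 1.3-fold lower number from compound 3 to compound 4 (0.10 log units; within the scatter) is expected to stay within the scatter. For compound 4 in this assay the estimate is 3000 nM, range 1400 nM to 7000 nM.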

Compound 4, half-maximal inhibitory concentration: 2370 nM
Estimate against measurement, compound 4: 1.3-fold (0.10 log units) above; the range from low to high includes it.
By their numbers in this assay, from the lowest: compounds 1, 4, 3 and 2 (each within the scatter of the next, the first and the last beyond it).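

In this assay, the lengthening from 3-(4-methylpiperazin-1-yl)propyl to 4-(4-methylpiperazin-1-yl)butyl is now measured on its own and stays within the scatter (a 1.6-fold lower number from compound 3 to compound 4 (0.20 log units; within the scatter)). Among these compounds, changing dimethylamino to (4-methylpiperazin-1-yl)methyl at this carbon changes the amine and the chain together and gives the first step at this position beyond the scatter, though a modest one (a 2.3-fold lower number from compound 2 to compound 4 (0.36 log units; beyond the scatter)). No evidence at hand accounts for either step.

A 4-(dimethylamino)butyl chain on the same core would show how the amine and the chain length each contribute to that step. A 5-(4-methylpiperazin-1-yl)pentyl chain, or a morpholine or piperidine in place of the methylpiperazine on the butyl chain, would test how far the flat response at this position extends.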